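Pyridine series: inhibition of topoisomerase 1 at a single concentration

The compounds below may be only part of what the source reports. "The series", "measured", "known", "first", "only" and "open" are said of these compounds alone.

Measured compounds:
- compound 1 `Oc1ccccc1-c1cc(-c2ccccc2)cc(-c2ccccc2O)n1`: "not determined" (no result reported)
- compound 2 `Oc1cccc(-c2cc(-c3ccccc3)cc(-c3ccccc3)n2)c1`: 0%
- compound 3 `Oc1cccc(-c2cc(-c3ccccc3)cc(-c3ccsc3)n2)c1`: 6.8%

In an assay on isolated protein for inhibition of DNA topoisomerase 1 (Homo sapiens), with a stated time of 30 min, tested at 20 uM (on this read-out higher numbers stand for a stronger effect at the one concentration tested and lower numbers for a weaker effect), compound 2 gives 0% and compound 3 gives 6.8%; compound 1 has no result. Within the data shown here, the one step in hand, a number 6.8 percentage points higher from compound 2 to compound 3 (within the scatter), lies within the scatter, so compound 3 stands within the scatter of compound 2, with nothing to set the two apart.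

Compound 4 `Oc1cccc(-c2cc(-c3ccccc3)cc(-c3cccc(O)c3)n2)c1` follows from compound 3 by 3-hydroxyphenyl in place of thiophen-3-yl on an aromatic carbon. Among the measured compounds shown here, no measured step covers this change; the only step available, a number 6.8 percentage points higher from compound 2 to compound 3 (within the scatter), exchanges the same position and gives no movement beyond the scatter. With both measured numbers near the floor of the read-out, compound 4 is expected to stay there, and the step of a number 0.8 percentage points lower from compound 3 to compound 4 (within the scatter) is expected to be within the scatter. Compound 4 is therefore estimated at 6%, in the range -5% to 20%.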

Compound 4, a percentage reported as inhibition, at one concentration (the size of the read-out at that concentration, not a potency): 10.5%
The estimate for compound 4 lay 4.5 percentage points below the measured number, within the range that was stated.
By their numbers in this assay, from the lowest: compounds 2, 3 and 4 (each within the scatter of the next, the first and the last beyond it).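

In this assay, hydroxy on the phenyl group at this place gives the first movement in the series that clears the scatter (a number 10.5 percentage points higher from compound 2 to compound 4 (beyond the scatter)). Exchanging thiophen-3-yl for 3-hydroxyphenyl gives no such separation (a number 3.7 percentage points higher from compound 3 to compound 4 (within the scatter)), so these two groups cannot be told apart here. Nothing measured bears on the cause of either step.

Still open, as far as these compounds go, is whether methoxy, an amine or a carboxylic acid in place of this hydroxy would keep or enlarge the step. Also open, from the compounds shown here alone, is whether hydroxy on the thiophen-3-yl ring would do the same.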